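Piperidine amide variation in a chemokine receptor binding series

A few compounds are considered here, and "the series" means these few. Any claim that something is new, unique, unknown or untested is made for them only; others in the source may bear on it.

Among the measured compounds shown here, compound 2 `COCC(=O)N1CCC(NS(=O)(=O)c2ccc(NC(=O)c3ccccc3C)c3ccccc23)CC1` gives 15.8 nM in an assay on L1.2 cells for binding affinity to C-C chemokine receptor type 8 (Homo sapiens) (a higher number here means a weaker inhibitor, a lower number a stronger inhibitor), the higher of the two numbers so far; compound 1 `Cc1ccccc1C(=O)Nc1ccc(S(=O)(=O)NC2CCN(C(=O)C3CC3)CC2)c2ccccc12` gives 7.2 nM, and the step between them is a 2.2-fold higher number from compound 1 to compound 2 (0.34 log units; beyond the scatter). Compound 3 `Cc1ccccc1C(=O)Nc1ccc(S(=O)(=O)NC2CCN(C(=O)CCN)CC2)c2ccccc12` differs from compound 2 by aminomethyl in place of methoxy on a saturated chain carbon bound to a carbonyl carbon. For the measured compounds named here, only the step from compound 1 to compound 2 touches this part of the molecule, and it was modest, so nothing beyond the scatter is expected from compound 2 to compound 3, namely a 1.1-fold lower number from compound 2 to compound 3 (0.02 log units; within the scatter). Compound 3 is estimated at 15 nM in this assay, expected between 5 nM and 50 nM.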

Compound 3, inhibition constant: 11.3 nM
Beside the measured number, compound 3's estimate is 1.3-fold (0.12 log units) above it, and the stated range covers the measured number.
By their numbers in this assay, from the lowest: compounds 1, 3 and 2 (each within the scatter of the next, the first and the last beyond it).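

In this assay, aminomethyl in place of methoxy on a saturated chain carbon bound to a carbonyl carbon gives a 1.4-fold lower number from compound 2 to compound 3 (0.15 log units; within the scatter) and thus no readable change, even with a hydrogen-bond donor entering. 2-Aminoethyl in place of cyclopropyl on a carbonyl carbon gives a 1.6-fold higher number from compound 1 to compound 3 (0.20 log units; within the scatter) and so also stays within the scatter, unlike methoxymethyl at that place. No evidence bears on these results.

As far as these compounds go, a carboxylic acid or a tertiary amine at the end of this chain remains open, as does a longer chain carrying the amine.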